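A few compounds are considered here, and "the series" means these few. Any claim that something is new, unique, unknown or untested is made for them only; others in the source may bear on it.

Working notes on the series. Compound 1 `COc1ccc(C(=O)Nc2nc(-c3ccccc3)cn3cc(-c4ccccc4)nc23)cc1` gives 25 nM in an assay on cells for displacement of a labelled ligand from transmembrane domain-containing protein TMIGD3 (Homo sapiens), read by scintillation counting, with a stated time of 120 min; a higher number here means a weaker inhibitor, a lower number a stronger inhibitor. Among the measured compounds shown here, compound 2 `O=C(Nc1nc(-c2ccccc2)cn2cc(-c3ccccc3)nc12)c1cccs1` gives 185 nM in the same assay, and the one step between the two measured compounds, a 7.4-fold higher number from compound 1 to compound 2 (0.87 log units; beyond the scatter), comes from thiophen-2-yl in place of 4-methoxyphenyl on the carbonyl carbon. For the measured compounds named here, compound 2 thus stands at the highest of the two numbers so far, with compound 1 the nearer and only neighbour.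

The next compound, compound 3 `O=C(Nc1nc(-c2ccccc2)cn2cc(-c3ccccc3)nc12)c1cccnc1`, differs from compound 2 in one place: pyridin-3-yl in place of thiophen-2-yl on a carbonyl carbon. Going by the values given here, the only measured step that bears on this position is the exchange of the aryl group on the carbonyl carbon, a 7.4-fold higher number from compound 1 to compound 2 (0.87 log units; beyond the scatter), which was modest and beyond the scatter, so swaps at this place can move the number. Whether pyridin-3-yl sits nearer the 4-methoxyphenyl of compound 1 or the thiophen-2-yl of compound 2 is not told by these two compounds alone. The expectation is therefore a small move, and the step of a 1.9-fold lower number from compound 2 to compound 3 (0.27 log units; within the scatter) is the estimate. For compound 3 the expected value in this assay is 100 nM, with a range from 30 nM to 350 nM.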

Compound 3, inhibition constant: 54 nM
The estimate for compound 3 lay 1.9-fold (0.27 log units) above the measured number, within the range that was stated.
By their numbers in this assay, from the lowest: compound 1; then compound 3; then compound 2.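

In this assay, pyridin-3-yl on the carbonyl carbon recovers much of the loss seen with thiophen-2-yl, with a 3.4-fold lower number from compound 2 to compound 3 (0.53 log units; beyond the scatter), yet it does not fully match 4-methoxyphenyl, with a 2.2-fold higher number from compound 1 to compound 3 (0.33 log units; beyond the scatter). This position therefore separates all three aryl groups, in the order 4-methoxyphenyl, pyridin-3-yl, thiophen-2-yl from the lowest number to the highest, and the thiophen-2-yl result no longer stands as a lone contrast to compound 1. Thiophen-2-yl and pyridin-3-yl have the same counts of ring hetero atoms and hydrogen-bond acceptors, so those counts do not distinguish them here, and nothing available explains the difference in their numbers.

The compounds shown leave open whether the step from thiophen-2-yl to pyridin-3-yl follows the change from a five-membered to a six-membered ring or the identity and placement of the hetero atom, which pyridin-4-yl, furan-2-yl and plain phenyl on the same carbonyl carbon would help to separate. They also leave open whether an aromatic ring is needed at all at this position, a question that a cyclohexyl group or a piperidin-4-yl group carrying a basic amine would address.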